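The compounds below may be only part of what the source reports. "The series", "measured", "known", "first", "only" and "open" are said of these compounds alone.

Compound 3 `ClCc1ccc(Cn2cnc3c(Cl)nc(Cl)nc32)cc1` and compound 1 `Nc1nc(Cl)c2ncn(Cc3ccc(CCl)cc3)c2n1` share one core and differ in a single group: amino in place of chloro on an aromatic carbon. In a functional assay on SF-539 cells (Homo sapiens) for cytotoxicity, read by sulforhodamine B assay, with a stated time of 48 h (on this read-out lower numbers stand for stronger inhibition of growth and higher numbers for weaker inhibition of growth), compound 3 gives 17000 nM, whereas compound 1 gives 3160 nM, a step of a 5.4-fold lower number from compound 3 to compound 1 (0.73 log units; beyond the scatter). Compound 2 `ClCc1cccc(Cn2cnc3c(Cl)nc(Cl)nc32)c1` is built from the same atoms as compound 3 joined differently; the difference between the two cores is not broken down here. In this assay compound 2 gives 2180 nM. Compound 4 `Nc1nc(Cl)c2ncn(Cc3cccc(CCl)c3)c2n1` has not been measured and relates to compound 2 by the same change: amino in place of chloro on an aromatic carbon. A comparable step is expected from compound 2 to compound 4, namely a 3.6-fold lower number from compound 2 to compound 4 (0.56 log units; beyond the scatter), because the earlier pair showed a 5.4-fold lower number from compound 3 to compound 1 (0.73 log units; beyond the scatter) and the surroundings of the change are identical. Compound 4 is therefore estimated at 600 nM, expected to lie between 200 nM and 2500 nM.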

Compound 4, concentration for 50% growth inhibition: 4670 nM
Compound 4: the middle estimate sits 7.8-fold (0.89 log units) below what was measured; the measured number lies above the stated range.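

In this assay, amino in place of chloro on an aromatic carbon did not repeat its earlier effect on the second core, giving a 2.1-fold higher number from compound 2 to compound 4 (0.33 log units; beyond the scatter). Set side by side, the two steps point in opposite directions: the same change on two cores in this assay, a 5.4-fold lower number (0.73 log units; beyond the scatter) from compound 3 to compound 1 and a 2.1-fold higher number (0.33 log units; beyond the scatter) from compound 2 to compound 4, 12-fold (1.06 log units) apart, beyond the scatter of two such steps. The size and even the direction of this change therefore depended on the core in these two pairs, but two pairs give no general rule and do not show what about the cores produces the difference.

The compounds shown leave open how a methoxy or methylamino group in the same place would behave on either core. They also leave open whether the same reversal would appear in other cell lines.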